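Cyclopropyl to Furanyl Ketones on Two Bicyclic Amine Cores

A few compounds are considered here, and "the series" means these few. Any claim that something is new, unique, unknown or untested is made for them only; others in the source may bear on it.

This set concerns four ketones built on bicyclic amine cores, tested in an assay on SHEP1 cells for displacement of a labelled ligand from Neuronal acetylcholine receptor; alpha4/beta2 (Homo sapiens), read by scintillation counting, with a stated time of 2 h; a lower number here means a stronger inhibitor, a higher number a weaker inhibitor. Compound 1 `O=C(C1CC1)[C@H]1C[C@H]2CNC[C@H]2C1` is the anchor of the series; in this assay compound 1 gives 0.5 nM. Compound 2 `O=C(c1ccco1)[C@H]1C[C@H]2CNC[C@H]2C1` shares the core of compound 1 and differs from it in one place: furan-2-yl in place of cyclopropyl on a carbonyl carbon. The result is a 26-fold higher number from compound 1 to compound 2 (1.41 log units; beyond the scatter), so in this assay compound 2 gives 13 nM.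

Compound 3 `O=C(C1CC1)[C@H]1C[C@@H]2CNC[C@@H](C2)C1` carries a different core, and in this assay compound 3 gives 43 nM. The difference between the two cores is not broken down here; the values simply show compound 3 well above compound 1 and above compound 2.

Compound 4 `O=C(c1ccco1)[C@H]1C[C@@H]2CNC[C@@H](C2)C1` has not yet been measured. It stands to compound 3 as compound 2 stands to compound 1: furan-2-yl in place of cyclopropyl on a carbonyl carbon. The two changes sit on a carbonyl carbon whose other neighbours are a saturated ring carbon in both cases, so this is the same change made on a second core.

For the measured compounds named here, the expectation for compound 4 rests on the single earlier example of this change, a 26-fold higher number from compound 1 to compound 2 (1.41 log units; beyond the scatter), applied to the value of compound 3, 43 nM. Because a 26-fold higher number from compound 1 to compound 2 (1.41 log units; beyond the scatter) was large, the step from compound 3 to compound 4 is expected to be a 16-fold higher number from compound 3 to compound 4 (1.21 log units; beyond the scatter), allowing that a change can land differently on a core that already binds less tightly. Compound 4 is therefore estimated at 700 nM in this assay, with a likely range from 150 nM to 3000 nM.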

Compound 4, inhibition constant: 110 nM
For compound 4 the middle estimate is 6.4-fold (0.80 log units) above the measured one; measured number below the stated range.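

In this assay, furan-2-yl in place of cyclopropyl on a carbonyl carbon gives a 2.6-fold higher number from compound 3 to compound 4 (0.41 log units; beyond the scatter), so on the second core this change again leaves a weaker inhibitor, as it did on the first. The direction of the change carried over from one core to the other, but its size did not, as the two steps set side by side show: the same change on two cores in this assay, a 26-fold higher number (1.41 log units; beyond the scatter) from compound 1 to compound 2 and a 2.6-fold higher number (0.41 log units; beyond the scatter) from compound 3 to compound 4, 10-fold (1.01 log units) apart, beyond the scatter of two such steps. A size measured on one core was therefore a poor guide to the size on the other in this pair, but two cores cannot show why the steps differ, nor what the same change would do on a third core.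

Going by these compounds, it remains open whether other groups on the carbonyl carbon, such as a phenyl ring, a thiophene ring or a plain methyl group, would also cost less on the core of compound 3 than on the core of compound 1. On these data alone, it is equally open whether an amide in place of the ketone would keep the same difference between the two cores.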